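Swapping the Aryl Group on the Ketone of Compound 2

The source may report more compounds than this note shows. Statements on the series, on what has been measured and on what is new or still open speak of the compounds shown alone.

Compound 2 `COc1ccccc1C(=O)c1sc2nc(-c3cccs3)ccc2c1N` carries a 2-methoxyphenyl group on a carbonyl carbon attached to the shared core. Going by the values given here, in a functional assay on WI-38 VA13 cells (Homo sapiens) for cytotoxicity (a higher number here means that more compound is needed for the effect, a lower number that less compound is needed), compound 2 gives 0.059 ug/mL, the lowest of the two numbers known so far. Compound 1 `CNc1c(C(=O)c2ccccc2)sc2nc(-c3cccs3)ccc12`, with a plain phenyl group on that carbonyl and a methylamino group on the core, gives 0.42 ug/mL in this assay. Compound 3 `CCOC(=O)c1sc2nc(-c3cccs3)ccc2c1N` gives only a limit in this assay, > 4 ug/mL. Compound 4 `Nc1c(C(=O)c2cccc(F)c2)sc2nc(-c3cccs3)ccc12` has not been measured yet; it differs from compound 2 in one place: 3-fluorophenyl in place of 2-methoxyphenyl on a carbonyl carbon. Among the compounds with values here, the only measured step touching this carbonyl carbon is an at least 67-fold higher number from compound 2 to compound 3 (1.83 log units; beyond the scatter), in which the aromatic ring is lost altogether. That step ends at the limit of > 4 ug/mL in this assay, at which 1 of the 3 values shown sits. Compound 4 keeps an aromatic ring on that carbon, so a step of that size is not expected; a change close to the scatter seems more likely. The estimated value for compound 4 in this assay is 0.1 ug/mL, expected to fall between 0.03 ug/mL and 0.4 ug/mL. The expected step is a 1.7-fold higher number from compound 2 to compound 4 (0.23 log units; within the scatter).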

Compound 4, half-maximal effective concentration: 0.025 ug/mL
Compound 4: the middle estimate sits 4.0-fold (0.60 log units) above what was measured; the measured number lies below the stated range.
By their numbers in this assay, from the lowest: compound 4; then compound 2; then compound 1. At a limit, above all of these: compound 3.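

In this assay, the step at this carbonyl carbon now runs the other way: a 2.4-fold lower number from compound 2 to compound 4 (0.37 log units; beyond the scatter), so the 2-methoxyphenyl group and its oxygen, the one hydrogen-bond acceptor in that group, are not required for a low number. Going by these compounds alone, earlier, the only measured change here removed the aromatic ring, whereas the comparison with the ethoxy compound now shows what a different aryl ring on this carbon can give, an at least 160-fold lower number from compound 3 to compound 4 (2.20 log units; beyond the scatter). That step starts from a limit and not from a number: the limit of > 4 ug/mL in this assay, at which 1 of the 4 values shown sits.

As far as these compounds go, with one change made at once, it stays open whether the fluorine's arrival or the methoxy group's departure accounts for the lower number. From the compounds shown here alone, it also stays open whether a cyclohexyl group, a ring that is not aromatic, would keep a low number on this carbonyl.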